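A few compounds are considered here, and "the series" means these few. Any claim that something is new, unique, unknown or untested is made for them only; others in the source may bear on it.

Measured compounds:
Compound 1, `O=C(CCc1ccccc1)[C@H](F)C(=O)NCc1ccccc1`: in an assay on HEK-293T cells for inhibition of phospholipase A and acyltransferase 4 (Homo sapiens), with stated times of 30 min and 20 min (on this read-out lower numbers stand for stronger inhibition and higher numbers for weaker inhibition), compound 1 reaches only a limit of the assay, > 10000 nM.
Compound 2, `O=C(CCc1ccc(Cl)cc1)C(=O)NCc1ccccc1`: in this assay compound 2 gives 2510 nM.
Compound 3, `O=C(CCc1ccc(Cl)cc1)C(=O)N1CCCCC1`: in this assay compound 3 again reaches only a limit of the assay, > 10000 nM.

Compound 3 therefore stands at the weak end of what has been seen: its result is a limit, not a number, and the same limit holds for compound 1, so that (the limit of > 10000 nM in this assay, at which 2 of the 3 values shown sit). Only compound 2, with its benzylamide, gives a measured value at all.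

Compound 4, `O=C(CCc1ccc(Cl)cc1)C(=O)N1CCOCC1`, keeps the whole of compound 3 apart from one piece: morpholin-4-yl in place of piperidin-1-yl on a carbonyl carbon. The amide nitrogen thus remains part of a saturated six-membered ring, and the rest of the molecule is unchanged.

Within the data shown here, no pair of measured compounds differs in just this way, so there is no measured step to lean on. Given that compound 3 shows only a limit, the step that the limit leaves unreadable from compound 3 to compound 4 is expected to be small in either direction and to stay within the usual scatter. Compound 4 is therefore estimated at 20000 nM, within a range from 5000 nM to 100000 nM, and most likely the assay will again report only a limit.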

Compound 4, half-maximal inhibitory concentration: > 10000 nM
Compound 4: a limit, no number (the forecaster's own chance of this, stated with the estimate: 75%); the middle value is on the limit's open side.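

Among these compounds, compound 3 and compound 4 both end at a limit of the assay rather than at a number, so no step between them can be read: (the limit of > 10000 nM in this assay, at which 3 of the 4 values shown sit). The compounds shown leave open whether morpholin-4-yl in place of piperidin-1-yl on a carbonyl carbon changes the inhibition at all.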